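The source may report more compounds than this note shows. Statements on the series, on what has been measured and on what is new or still open speak of the compounds shown alone.

Series notes. Of the compounds shown here, two are measured so far. Compound 1 `COC(=O)N[C@@H]1Cc2ccc(NC(=O)c3ccccc3-c3ccc(C(F)(F)F)cc3)cc2C1` gives in an assay for inhibition of apolipoprotein B-100 (Homo sapiens), tested at 100 nM (on this read-out higher numbers stand for weaker inhibition and lower numbers for stronger inhibition), a value of 5.2 nM. Compound 2 `Cc1ccc(-c2c(C)cccc2C(=O)Nc2ccc3c(c2)CC(NS(=O)(=O)c2ccccc2)C3)cc1` gives in this assay a value of 2.5 nM, the lowest of the two numbers, with compound 1 standing higher by a gap beyond the scatter. Compound 3 `Cc1cccc(C(=O)Nc2ccc3c(c2)CC(NS(=O)(=O)c2ccccc2)C3)c1-c1ccc(Cl)cc1` is not yet measured; it differs from compound 2 by chloro in place of methyl on an aromatic carbon. Among the measured compounds shown here, no measured pair shows this change, so the expected step from compound 2 to compound 3 is small, no change at the digits printed from compound 2 to compound 3 (within the scatter), in no clear direction beyond the scatter. Compound 3 is estimated at 2.5 nM, within 1 nM to 6 nM.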

Compound 3, half-maximal inhibitory concentration: 2.4 nM
Beside the measured number, compound 3's estimate is 1.0-fold (0.02 log units) above it, within the range that was stated.
By their numbers in this assay, from the lowest: compounds 3 and 2 (each within the scatter of the next); then compound 1.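

In this assay, among the compounds shown here, the change from 4-methylphenyl to 4-chlorophenyl gives a 1.0-fold lower number from compound 2 to compound 3 (0.02 log units; within the scatter), the first direct reading at this position. Chloro and methyl on this aromatic carbon, para to a large group, therefore cannot be told apart on this read-out, and a value in the low range holds with either group. No available data speak to the basis of this match.

Going by these compounds, whether this position accepts a larger or charged group, such as a methoxy, an amine or a carboxylic acid, remains open. On these data alone, it is also open whether the same exchange reads alike with the other parts of the series varied.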